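The compounds below may be only part of what the source reports. "The series", "measured", "known", "first", "only" and "open" are said of these compounds alone.

Compound 3 `O=C([C@@H]1CCCN(S(=O)(=O)c2ccc(S(=O)(=O)C3CCC3)cc2)C1)N1CCC(F)(F)CC1` gives the lowest number among three measured compounds in a functional assay on MIA PaCa-2 cells (Homo sapiens) for inhibition, read by MTT assay, with a stated time of 7 days (a lower number here means a stronger inhibitor, a higher number a weaker inhibitor), at 9 nM. Compound 2 `CCC(CC)S(=O)(=O)c1ccc(S(=O)(=O)N2CCC[C@@H](C(=O)N3CCC(F)(F)CC3)C2)cc1` gives 13 nM in this assay, and the step of a 1.4-fold lower number from compound 2 to compound 3 (0.16 log units; within the scatter) lies within the scatter, so the two cannot be ranked. Compound 1 `O=C([C@@H]1CCCN(S(=O)(=O)c2ccc(S(=O)(=O)N3CC[C@@H](O)C3)cc2)C1)N1CCC(F)(F)CC1` gives 210 nM, and the steps of a 16-fold lower number from compound 1 to compound 2 (1.21 log units; beyond the scatter) and a 23-fold lower number from compound 1 to compound 3 (1.37 log units; beyond the scatter) are both large. Compound 4 `O=C([C@@H]1CCCN(S(=O)(=O)c2ccc(S(=O)(=O)C3COC3)cc2)C1)N1CCC(F)(F)CC1` differs from compound 3 in one place: oxetan-3-yl in place of cyclobutyl on a sulfonyl sulfur. The measured steps do not contain this exact change. The steps from compound 1 show that a group on the sulfonyl sulfur carrying a hydrogen-bond donor and acceptor gave a much higher number than an all-carbon group, while the all-carbon swap between compound 2 and compound 3 changed little. Compound 4 brings in one hydrogen-bond acceptor but no donor, so a moderate rise in the number is expected, smaller than the steps from compound 1. The estimated step is a 2.8-fold higher number from compound 3 to compound 4 (0.44 log units; beyond the scatter). Compound 4 is therefore estimated at 25 nM, with a range from 9 nM to 70 nM.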

Compound 4, half-maximal inhibitory concentration: 110 nM
Compound 4: middle estimate off by 4.4-fold (0.64 log units), on the low side; the measured number lies above the stated range.
By their numbers in this assay, from the lowest: compounds 3 and 2 (each within the scatter of the next); then compounds 4 and 1 (each within the scatter of the next).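

With the group's size unchanged at the same count of heavy atoms, putting an oxygen in place of one ring carbon on this sulfonyl sulfur has a large effect in this assay (a 12-fold higher number from compound 3 to compound 4 (1.09 log units; beyond the scatter)), and the comparison with the open-chain pentan-3-yl group also goes against the oxetane (an 8.5-fold higher number from compound 2 to compound 4 (0.93 log units; beyond the scatter)). A hydrogen-bond acceptor without a donor is thus enough here to give a number that cannot be separated from that of the 3-hydroxypyrrolidin-1-yl group of compound 1 (a 1.9-fold lower number from compound 1 to compound 4 (0.28 log units; within the scatter)). No measurement shown explains why this one atom matters so much.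

As far as these compounds go, it remains open whether an amine such as azetidin-3-yl on this sulfonyl sulfur would behave like the oxetane. Also open, from the compounds shown here alone, is whether a fluorine-bearing cyclobutyl would stay close to the all-carbon groups.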